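Pyrrole for Dimethylamino on a Phenyl-Bearing Core

A few compounds are considered here, and "the series" means these few. Any claim that something is new, unique, unknown or untested is made for them only; others in the source may bear on it.

Measured so far in a functional assay on K562 cells (Homo sapiens) for antiproliferative activity, read by MTT assay, with a stated time of 48 h; on this read-out lower numbers stand for stronger inhibition and higher numbers for weaker inhibition:
compound 1 `Cn1cc(C2=C(c3nn(CCCn4cccc4)c4ncccc34)C(=O)NC2=O)c2ccccc21` gives 21600 nM
compound 2 `CN(C)CCCn1nc(C2=C(c3cn(C)c4ccccc34)C(=O)N(c3ccccc3)C2=O)c2cccnc21` gives 1700 nM
compound 3 `CN(C)CCCn1nc(C2=C(c3cn(C)c4ccccc34)C(=O)NC2=O)c2cccnc21` gives 50400 nM

Compound 4 `Cn1cc(C2=C(c3nn(CCCn4cccc4)c4ncccc34)C(=O)N(c3ccccc3)C2=O)c2ccccc21` has not been measured. It differs from compound 2 by 1H-pyrrol-1-yl in place of dimethylamino on a saturated chain carbon, three bonds along the chain from an aromatic nitrogen. The same change has been made once before, from compound 3 to compound 1, where it reads 1H-pyrrol-1-yl in place of dimethylamino on a saturated chain carbon, three bonds along the chain from an aromatic nitrogen and gave a 2.3-fold lower number from compound 3 to compound 1 (0.37 log units; beyond the scatter). The two cores differ in turn by phenyl in place of hydrogen on an amide-type nitrogen in a ring, a change that brought a 30-fold higher number from compound 2 to compound 3 (1.47 log units; beyond the scatter), leaving compound 2 the lowest of the three. With a single earlier example, the expectation for compound 4 rests on it alone: a step of about a 2.1-fold lower number from compound 2 to compound 4 (0.33 log units; beyond the scatter) is expected, beside the earlier 2.3-fold lower number from compound 3 to compound 1 (0.37 log units; beyond the scatter). Compound 4 is therefore estimated at 800 nM, within 300 nM to 2500 nM.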

Compound 4, half-maximal inhibitory concentration: 36600 nM
For compound 4 the middle estimate is 46-fold (1.66 log units) below the measured one; the whole stated range lies below it.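

Swapping dimethylamino for 1H-pyrrol-1-yl did not carry over between the two cores: on the phenyl-bearing core it brought a 22-fold higher number from compound 2 to compound 4 (1.33 log units; beyond the scatter), so the earlier step was no guide here: the same change on two cores in this assay, a 2.3-fold lower number (0.37 log units; beyond the scatter) from compound 3 to compound 1 and a 22-fold higher number (1.33 log units; beyond the scatter) from compound 2 to compound 4, 50-fold (1.70 log units) apart, beyond the scatter of two such steps Phenyl on the ring's amide-type nitrogen depends on the chain in the same way, since with the 1H-pyrrol-1-yl chain there is only a 1.7-fold higher number from compound 1 to compound 4 (0.23 log units; within the scatter), which is no real change, and the large gain seen with dimethylamino is absent: the same change on two cores in this assay, a 30-fold higher number (1.47 log units; beyond the scatter) from compound 2 to compound 3 and a 1.7-fold lower number (0.23 log units; within the scatter) from compound 4 to compound 1, 50-fold (1.70 log units) apart, beyond the scatter of two such steps The two changes therefore do not add up independently in these four compounds, but this does not show why, or whether the same holds for other groups.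

On these data alone, it remains open whether another amine on the chain, such as morpholine, or a longer chain would keep the activity of compound 2 (1700 nM). A methyl group in place of phenyl on the amide-type nitrogen is also untested among the compounds shown.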